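Acetylating the Amine of Compound 2

This account rests on a few compounds, and the source may have more. Where it says the series, first, only, none or still open, it means among the compounds named here.

Of the compounds shown here, two on a shared core have been tested in a functional assay on the whole organism with Canis familiaris (Canis lupus familiaris) as the target, at a dose of 8 mg/kg by the oral route; on this read-out lower numbers stand for a weaker effect and higher numbers for a stronger effect at the one dose given. Compound 1 `Cc1nc2c(OCc3ccsc3)cccn2c1N` gives 88% in this assay. Compound 2 `Cc1nc2c(CCc3ccccc3)cccn2c1N` gives 52% in this assay, the lower of the two numbers, with a gap to compound 1 that lies beyond the scatter. Compound 3 `CC(=O)Nc1c(C)nc2c(CCc3ccccc3)cccn12` differs from compound 2 in one place: acetyl in place of hydrogen on a nitrogen on an aromatic ring. Among the measured compounds shown here, no measured pair shows this change, so its direction cannot be read from the data; only a small step, not beyond the scatter, is expected a number 7 percentage points lower from compound 2 to compound 3 (within the scatter). Compound 3 is expected to give about 45% in this assay, within 15% to 75%.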

Compound 3, a percentage reported as inhibition, in the whole organism at one dose (the size of the read-out at that dose, not a potency): 16%
Estimate against measurement, compound 3: 29 percentage points above; low and high end bracket the measured number.
By their numbers in this assay, from the lowest: compound 3; then compound 2; then compound 1.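

Acetyl on this nitrogen matters: in this assay the amino to acetamido change gives a number 36 percentage points lower from compound 2 to compound 3 (beyond the scatter) on the shared core. This nitrogen is therefore a place where one small change moves the read-out at the single dose given, and here acetyl goes with the weaker effect. No measurement at hand bears on why the number falls. From the compounds shown here alone, it remains open whether a longer acyl chain such as propionyl, or a single methyl, on this nitrogen would give a similar step. Going by these compounds, it also remains open whether acetyl would do the same on compound 1.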